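This account rests on a few compounds, and the source may have more. Where it says the series, first, only, none or still open, it means among the compounds named here.

Compound 1 `COC(=O)C1=C(C)N=C(C)/C(=C(\O)OC)C1c1cccc(N)c1` carries a 3-aminophenyl group on a saturated ring carbon of the shared core. In a functional assay (muscle tissue) with Cavia porcellus as the target (on this read-out higher numbers stand for an effect only at larger amounts of compound and lower numbers for an effect already at smaller amounts), compound 1 gives 2000 nM, the highest number among the three measured compounds. Compound 2 `COC(=O)C1=C(C)N=C(C)/C(=C(\O)OC)C1c1ccccc1Br` gives 7.59 nM and compound 3 `COC(=O)C1=C(C)N=C(C)/C(=C(\O)OC)C1c1ccc(Br)cc1` gives 540 nM. The measured steps are a 260-fold lower number from compound 1 to compound 2 (2.42 log units; beyond the scatter) and a 3.7-fold lower number from compound 1 to compound 3 (0.57 log units; beyond the scatter), and between the two bromo compounds a 71-fold higher number from compound 2 to compound 3 (1.85 log units; beyond the scatter). Compound 4 `COC(=O)C1=C(C)N=C(C)/C(=C(\O)OC)C1c1cccc(OC(=O)c2ccccc2)c1` differs from compound 1 by benzoyloxy in place of amino on an aromatic carbon. Both measured steps from compound 1 exchange the 3-aminophenyl for a bromophenyl, so each changes the group and its position at once; neither tests a new group on the same aromatic carbon, meta to a large group. They show only that removing the amino lowered the number in both cases, by a modest and by a large amount. Compound 4 is therefore expected to show a 2.5-fold lower number from compound 1 to compound 4 (0.40 log units; beyond the scatter), a modest lowering with wide uncertainty. For compound 4 the estimate is 800 nM, in the range 150 nM to 4000 nM.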

Compound 4, half-maximal effective concentration: 6310 nM
Compound 4: the middle estimate sits 7.9-fold (0.90 log units) below what was measured, and the stated range ends below it.
By their numbers in this assay, from the lowest: compound 2; then compound 3; then compound 1; then compound 4.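

In this assay, replacing amino with benzoyloxy on the same aromatic carbon, meta to a large group, gives a 3.2-fold higher number from compound 1 to compound 4 (0.50 log units; beyond the scatter). This is the first change shown that leaves the position untouched, and its direction is opposite to that of the two earlier steps away from the 3-aminophenyl compound, a 260-fold lower number from compound 1 to compound 2 (2.42 log units; beyond the scatter) and a 3.7-fold lower number from compound 1 to compound 3 (0.57 log units; beyond the scatter). Losing the amino group therefore does not lower the number in every case, and no measurement at hand accounts for this rise.

The compounds shown leave open how a hydroxyl, a methoxy or a benzoylamino group on this aromatic carbon would compare with amino and benzoyloxy. They also leave open what a bromo group would do on this carbon, as the bromo compounds shown are the 2-bromophenyl and 4-bromophenyl ones.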